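A methoxy for a fluoro on a cyclobutyl amide

A few compounds are considered here, and "the series" means these few. Any claim that something is new, unique, unknown or untested is made for them only; others in the source may bear on it.

Of the compounds shown here, two sharing one core have been measured in an assay on HEK293 cells for negative allosteric modulation of metabotropic glutamate receptor 5 (Homo sapiens), read by FLIPR, with a stated time of 1 h; on this read-out higher numbers stand for weaker inhibition and lower numbers for stronger inhibition. Compound 1 `O=C(C1CC12CCC2)N1CCc2nc(C#Cc3ccccc3)sc2C1` carries its larger saturated group on a carbonyl carbon. In this assay compound 1 returns only the assay limit, > 10000 nM, rather than a number. Compound 2 `O=C(C1CC(F)C1)N1CCc2nc(C#Cc3ccccc3)sc2C1` carries a 3-fluorocyclobutyl group in that place. In this assay compound 2 likewise returns only the limit, > 10000 nM. The step that the two limits leave unreadable from compound 1 to compound 2 therefore cannot be read. For the measured compounds named here, because the limit of > 10000 nM in this assay, at which 2 of the 2 values shown sit, holds both values, compound 2 stands exactly where the only other measured compound stands, with no real number to anchor it.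

Compound 3 `COC1CC(C(=O)N2CCc3nc(C#Cc4ccccc4)sc3C2)C1` is the next step: methoxy in place of fluoro on a saturated ring carbon. No measured step covers this change, and the single step shown, from compound 1 to compound 2, has no readable size. The data thus give no reason to expect a gain or a loss in this assay beyond the scatter. Compound 3 is expected to stay near the limit, at an estimated 10000 nM within 3000 nM to 30000 nM. The step of a number no higher from compound 2 to compound 3 (the limit leaves the size open) is accordingly expected to be essentially none.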

Compound 3, half-maximal inhibitory concentration: > 10000 nM
Compound 3: no number, only a limit; the forecaster's own chance of this, stated with the estimate: 75%; the middle value lies on the limit itself.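

In this assay compound 3 returns only a limit, as do compound 1 and compound 2, so no step among these three compounds can be read. Left open is whether any group on the carbonyl carbon of the shared core can give a real number in this assay and how methoxy and fluoro compare on the four-membered ring.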